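The source may report more compounds than this note shows. Statements on the series, on what has been measured and on what is new or still open speak of the compounds shown alone.

Three compounds share one core and differ only in the side chain attached through an oxygen on a saturated carbon. Compound 1 `CCCC(O)CC(=O)O[C@H](CC=C(C)C)C1=CC(=O)c2c(O)ccc(O)c2C1=O` carries a (2-hydroxypentyl)carbonyl group there; compound 2 `CCCCC(O)CC(=O)O[C@H](CC=C(C)C)C1=CC(=O)c2c(O)ccc(O)c2C1=O` carries a (2-hydroxyhexyl)carbonyl group; compound 3 `CC(=O)OCCO[C@H](CC=C(C)C)C1=CC(=O)c2c(O)ccc(O)c2C1=O` carries a 2-acetoxyethyl group. In a functional assay on HeLa cells (Homo sapiens) for cytotoxicity, read by MTT assay (on this read-out lower numbers stand for stronger inhibition and higher numbers for weaker inhibition), compound 1 gives 59300 nM, a number that sits within the usual scatter of both compound 2, which gives 72200 nM, and compound 3, which gives 41500 nM. The two measured steps from compound 1, a 1.2-fold higher number from compound 1 to compound 2 (0.09 log units; within the scatter) and a 1.4-fold lower number from compound 1 to compound 3 (0.16 log units; within the scatter), therefore show that neither a longer chain nor a quite different side group moved the number in this assay beyond what repeated measurements would vary.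

Compound 4 `CC(C)=CC[C@@H](OC(=O)C1CCCCO1)C1=CC(=O)c2c(O)ccc(O)c2C1=O` is made from compound 1 by the change (oxan-2-yl in place of 2-hydroxypentyl on a carbonyl carbon). Both earlier steps on this same side chain stayed within the scatter, so no step beyond the scatter is expected in either direction. The step of a 1.0-fold lower number from compound 1 to compound 4 (0.00 log units; within the scatter) is thus expected to stay within the scatter. Compound 4 is expected to give about 59000 nM, with a range from 25000 nM to 140000 nM.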

Compound 4, half-maximal inhibitory concentration: > 100000 nM
Compound 4 gave a limit, no number (the forecaster's own chance of this, stated with the estimate: 10%); middle value at least 1.6-fold (0.22 log units) from the limit.
By their numbers in this assay, from the lowest: compounds 3, 1 and 2 (each within the scatter of the next). At a limit, above all of these: compound 4.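

Compound 4 gives only a limit of this assay, not a number: the limit of > 100000 nM in this assay, at which 1 of the 4 values shown sits. Going by these compounds alone, this is the first change at this position with a step beyond the scatter, an at least 2.4-fold higher number from compound 3 to compound 4 (0.38 log units; beyond the scatter), so the side group here can matter to the read-out, and the change points towards weaker inhibition. The floors of the other two steps, an at least 1.6-fold higher number from compound 1 to compound 4 (0.22 log units; that floor lies within the scatter) and an at least 1.3-fold higher number from compound 2 to compound 4 (0.14 log units; that floor lies within the scatter), lie within the scatter, so swapping the open chains for oxan-2-yl has no measured size, only a lower bound.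

The change removes the hydrogen-bond donor and adds the ring together, so the compounds shown cannot separate the two. An open chain ending in a methoxy group, or a six-membered ring carrying a hydroxyl group, would be needed to tell them apart.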